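A Side Chain Swap at the Tolerance Limit

The compounds below may be only part of what the source reports. "The series", "measured", "known", "first", "only" and "open" are said of these compounds alone.

- Compound 1 `O=c1c(C2=CS(=O)(=O)c3cc(O)ccc3N2)c(O)c2cc(F)ccc2n1Cc1ccc(F)cc1` gives > 50000 nM
- Compound 2 `CS(=O)(=O)Nc1ccc2c(c1)S(=O)(=O)C=C(c1c(O)c3c(Cl)cccc3n(Cc3ccc(F)cc3)c1=O)N2` gives > 50000 nM
- Compound 3 `COc1cc(Cn2c(=O)c(C3=CS(=O)(=O)c4cc(NS(C)(=O)=O)ccc4N3)c(O)c3cc(F)ccc32)ccc1F` gives > 50000 nM

In an ADME assay on 2209-23 cells (Homo sapiens) for cytotoxicity, read by WST assay (a higher number here means that more compound is tolerated, a lower number that less compound is tolerated), compound 3 stands at a limit (> 50000 nM) and not at a number. The two other measured compounds share that limit (the limit of > 50000 nM in this assay, at which 3 of the 3 values shown sit). Compound 4 `COC(C)(C)CCn1c(=O)c(C2=CS(=O)(=O)c3cc(NS(C)(=O)=O)ccc3N2)c(O)c2cc(F)ccc21` has 2-methoxy-2-methylpropyl in place of 4-fluoro-3-methoxyphenyl, on a saturated chain carbon bound to an aromatic nitrogen (2-methoxy-2-methylpropyl in place of 4-fluoro-3-methoxyphenyl on a saturated chain carbon bound to an aromatic nitrogen). For the measured compounds named here, no measured step shows what such a change does in this assay, so only the shared limit can guide an expectation. No step beyond the scatter is expected (an at least 1.1-fold lower number from compound 3 to compound 4 (0.04 log units; that floor lies within the scatter)). Compound 4 is estimated at 45000 nM (expected range 20000 nM to 50000 nM).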

Compound 4, half-maximal cytotoxic concentration: > 50000 nM
Compound 4 ended at the assay's limit; the forecaster's own chance of this, stated with the estimate: 70%; middle value at least 1.1-fold (0.04 log units) from the limit.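

Compound 3 and compound 4 both stand at a limit in this assay, so no step between them can be read: the limit of > 50000 nM in this assay, at which 4 of the 4 values shown sit.

The compounds shown leave open at what concentration any of them becomes cytotoxic, and whether this side chain swap changes that concentration.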